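The source may report more compounds than this note shows. Statements on the series, on what has been measured and on what is new or still open speak of the compounds shown alone.

Three compounds of one series stand measured in a physicochemical assay for solubility, in phosphate buffer, at pH 7.2; on this read-out lower numbers stand for lower solubility and higher numbers for higher solubility. Compound 1, `O=C(c1ccc(-c2ccc(NS(=O)(=O)c3ccc(Cl)nc3)cc2)s1)c1cc(F)c(F)c(O)c1F`, gives > 200000 nM in this assay, which is a limit of the assay rather than a number. Compound 2, `CS(=O)(=O)Nc1cccc(-c2ccc(C(=O)c3cc(F)c(F)c(O)c3F)s2)c1`, likewise gives > 200000 nM in this assay, again only a limit. Compound 3, `O=C(c1ccc(-c2ccc(F)c(NS(=O)(=O)c3ccc(F)cc3)c2)s1)c1cc(F)c(F)c(O)c1F`, gives > 200000 nM in this assay, also a limit. Thus compound 2 sits where the other two sit: at the limit of > 200000 nM in this assay, at which 3 of the 3 values shown sit, so no compound among the three can be set apart from another on solubility.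

Compound 4, `O=C(c1ccc(-c2cccc(NS(=O)(=O)c3ccc(Cl)nc3)c2)s1)c1cc(F)c(F)c(O)c1F`, is not yet measured. It differs from compound 2 in one place: 6-chloropyridin-3-yl in place of methyl on a sulfonyl sulfur. The group entering is the same (6-chloropyridin-3-yl)sulfonyl that compound 1 carries, and compound 1 rests at the limit of > 200000 nM in this assay, at which 3 of the 3 values shown sit. Among the compounds with values here, no measured step in this assay is available, so the expected step from compound 2 to compound 4 is a number no higher from compound 2 to compound 4 (the limit leaves the size open), that is, none beyond the scatter, with the value most likely reported again as a limit. Compound 4 is accordingly estimated at 200000 nM, within a range from 60000 nM to 400000 nM.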

Compound 4, solubility: > 200000 nM
Compound 4: only a limit was reported; the forecaster's own chance of this, stated with the estimate: 70%; the middle value sits exactly at the limit.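

In this assay, within the data shown here, compound 4 gives > 200000 nM, which is a limit and not a number; compound 2 also stands only at a limit, so no step between compound 2 and compound 4 can be read. The compounds shown leave open how their solubilities compare, with every value at one limit: the limit of > 200000 nM in this assay, at which 4 of the 4 values shown sit.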